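This account rests on a few compounds, and the source may have more. Where it says the series, first, only, none or still open, it means among the compounds named here.

Three measured compounds share one core and differ only in the aryl group on the aromatic nitrogen. Compound 1 `COc1cc2c(Oc3ccc(NC(=O)c4nn(-c5ccccc5)c(=O)c5ccccc45)cc3F)ccnc2cc1OCCCN1CCCC1` carries an unsubstituted phenyl there, and in a functional assay on MKN-45 cells (Homo sapiens) for cytotoxicity, read by MTT assay, with a stated time of 72 h (a higher number here means a weaker inhibitor, a lower number a stronger inhibitor), compound 1 gives 530 nM. Compound 2 `COc1cc2c(Oc3ccc(NC(=O)c4nn(-c5cccc(F)c5)c(=O)c5ccccc45)cc3F)ccnc2cc1OCCCN1CCCC1` carries a 3-fluorophenyl, and in this assay compound 2 gives 160 nM. Compound 3 `COc1cc2c(Oc3ccc(NC(=O)c4nn(-c5ccccc5F)c(=O)c5ccccc45)cc3F)ccnc2cc1OCCCN1CCCC1` carries a 2-fluorophenyl, and in this assay compound 3 gives 140 nM. Compound 3 thus has the lowest number of the three, though its gap to compound 2 is small: a 1.1-fold lower number from compound 2 to compound 3 (0.06 log units; within the scatter).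

Compound 4 `COc1cc2c(Oc3ccc(NC(=O)c4nn(-c5ccc(Br)cc5)c(=O)c5ccccc45)cc3F)ccnc2cc1OCCCN1CCCC1` changes the aryl group once more: 4-bromophenyl in place of 2-fluorophenyl on an aromatic nitrogen. For the measured compounds named here, no measured step involves bromine or a 4-bromophenyl ring. Going by the values given here, the only guidance comes from the fluoro steps, a 3.3-fold lower number from compound 1 to compound 2 (0.52 log units; beyond the scatter) and a 3.8-fold lower number from compound 1 to compound 3 (0.58 log units; beyond the scatter), which show that a halogen on this phenyl lowered the number from compound 1 wherever it sat. The expectation for compound 4 in this assay is therefore a number near that of compound 3, an estimated 1.4-fold higher number from compound 3 to compound 4 (0.15 log units; within the scatter), with a wide range. Compound 4 is estimated at 200 nM, between 60 nM and 700 nM.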

Compound 4, half-maximal inhibitory concentration: 230 nM
Compound 4: middle estimate off by 1.2-fold (0.06 log units), on the low side; low and high end bracket the measured number.
By their numbers in this assay, from the lowest: compounds 3, 2 and 4 (each within the scatter of the next); then compound 1.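

Bromine now joins fluorine as a halogen that lowers the number on this aryl group, with a 2.3-fold lower number from compound 1 to compound 4 (0.36 log units; beyond the scatter), so in this assay the drop from the unsubstituted phenyl no longer rests on fluorine alone or on the two earlier ring positions. Swapping either fluorophenyl for 4-bromophenyl leaves the result within the scatter, with a 1.6-fold higher number from compound 3 to compound 4 (0.22 log units; within the scatter) and a 1.4-fold higher number from compound 2 to compound 4 (0.16 log units; within the scatter), so all three halogenated compounds stand apart from compound 1 but not from each other. No available evidence accounts for this result.

Compound 4 differs from compound 2 and compound 3 in both the halogen and its place on the ring, and the compounds shown do not separate these two changes. Going by these compounds, whether a methoxy group or an amine on this phenyl would also lower the number remains open.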